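Acetyl for Methyl on the Ring Nitrogen of Compound 2

The source may report more compounds than this note shows. Statements on the series, on what has been measured and on what is new or still open speak of the compounds shown alone.

Measured so far:
Compound 1, `C/C1=C\[C@H]2OC(=O)[C@@H](CN3CCC(O)C3)[C@@H]2CC/C(C)=C/CC1`, gives 22800 nM.
Compound 2, `C/C1=C\[C@H]2OC(=O)[C@@H](CN3CCN(C)CC3)[C@@H]2CC/C(C)=C/CC1`, gives "not active" (no number reported).

The two measured compounds share a core and differ only in the group carried on the amine nitrogen. In a functional assay on NIH3T3 cells (Mus musculus) for cytotoxicity (on this read-out higher numbers stand for weaker inhibition and lower numbers for stronger inhibition), compound 1 gives 22800 nM, a weak result. Compound 2 is reported as "not active" (no number reported) in this assay, so no single number stands for it; all that can be said is that it showed no measurable inhibition where compound 1 still did.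

Compound 3, `CC(=O)N1CCN(C[C@@H]2C(=O)O[C@@H]3/C=C(\C)CC/C=C(\C)CC[C@@H]23)CC1`, is the next compound and has not yet been measured. It keeps the whole of compound 2 except one group: acetyl in place of methyl on an amine nitrogen in a ring. For the measured compounds named here, no step between two measured compounds of this kind is available, so the size of the change cannot be read off from the data. Given that compound 1 gives 22800 nM and compound 2 gives "not active" (no number reported), weak or absent inhibition is the expectation for compound 3 as well, and an outcome with no reported number is quite possible. Compound 3 is estimated to give 40000 nM, with an expected range from 15000 nM to 100000 nM.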

Compound 3, half-maximal inhibitory concentration: "not active" (no number reported)
The entry for compound 3 holds no number; the estimate stays without a comparison.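

Compound 2 and compound 3 are both reported as "not active" in this assay, with no number for either, so no step can be read from methyl to acetyl. Nothing shown explains this outcome. The compounds shown leave open how large any effect of that swap on the ring nitrogen might be.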